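The compounds below may be only part of what the source reports. "The series", "measured", "known", "first", "only" and "open" are said of these compounds alone.

The measured compounds:

Compound 1, `Cn1ccc2c(Oc3ccc(NC(=O)c4cc5cccnc5n(-c5ccc(Br)cc5)c4=O)cc3)ncnc21`, in a functional assay on A549 cells (Homo sapiens) for cytotoxicity, read by MTT assay, with a stated time of 72 h (on this read-out lower numbers stand for stronger inhibition and higher numbers for weaker inhibition), compound 1 gives 52200 nM.
Compound 2, `Cn1ccc2c(Oc3ccc(NC(=O)c4cc5cccnc5n(-c5ccc(Br)cc5)c4=O)cc3F)ncnc21`, in this assay compound 2 gives 42200 nM.
Compound 3, `O=C(Nc1ccc(Oc2ncnc3[nH]ccc23)c(F)c1)c1cc2cccnc2n(-c2ccccc2)c1=O`, in this assay compound 3 gives 45500 nM.

Compound 1 and compound 2 share a core and differ in one place: fluoro in place of hydrogen on an aromatic carbon. That change made a 1.2-fold lower number from compound 1 to compound 2 (0.09 log units; within the scatter). The difference between the core of compound 3 and that of compound 1 is not broken down here; their values in this assay lie within the scatter of one another, as do those of compound 3 and compound 2.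

Compound 4, `O=C(Nc1ccc(Oc2ncnc3[nH]ccc23)c(F)c1)c1cc2cccnc2n(-c2ccc(F)cc2)c1=O`, has not yet been measured. It differs from compound 3 by fluoro in place of hydrogen on an aromatic carbon. This is the same kind of change as that from compound 1 to compound 2, though the surroundings differ: there the fluoro sat ortho to a large group and meta to a large group, here it sits para to a large group, where the same difference cut one bond further out reads phenyl to 4-fluorophenyl. Because the earlier step was a 1.2-fold lower number from compound 1 to compound 2 (0.09 log units; within the scatter), compound 4 is expected to show a step of a 1.1-fold lower number from compound 3 to compound 4 (0.06 log units; within the scatter) in this assay, within the scatter. The estimate for compound 4 is 40000 nM, between 20000 nM and 90000 nM.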

Compound 4, half-maximal inhibitory concentration: 5290 nM
Estimate against measurement, compound 4: 7.6-fold (0.88 log units) above, outside the stated range (below it).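

Fluoro in place of hydrogen, here para to a large group on a six-membered aromatic ring, gave an 8.6-fold lower number from compound 3 to compound 4 (0.93 log units; beyond the scatter) in this assay. The same kind of change therefore did not carry over at the same size from one core to the other: the same change on two cores in this assay, a 1.2-fold lower number (0.09 log units; within the scatter) from compound 1 to compound 2 and an 8.6-fold lower number (0.93 log units; beyond the scatter) from compound 3 to compound 4, 7.0-fold (0.84 log units) apart, beyond the scatter of two such steps. This shows that a step measured on one core cannot be taken as a guide to the step on another in this series, but it does not show what sets the two apart, as the two pairs differ in their cores and also in where the fluoro sits, and one pair on each core gives no rule.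

Going by these compounds, it remains open whether the lower number belongs to fluoro in particular or would also appear with chloro, methyl, methoxy or an amine in the same place on the phenyl of compound 3. The compounds shown also leave open whether phenyl to 4-fluorophenyl would give a step of this size on any further core.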